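The compounds below may be only part of what the source reports. "The series", "measured", "known", "first", "only" and "open" are said of these compounds alone.

Measured so far:
compound 1 `COc1ccc(C(=O)/C=C/c2ccc(OCc3cn(Cc4ccccc4Br)nn3)cc2)cc1` — 52%
compound 2 `COc1ccc(C(=O)/C=C/c2ccc(OCc3cn(Cc4ccc(Br)cc4)nn3)cc2)cc1` — 50%

Compound 2 stands lowest of the two numbers in a functional assay on A549 cells (Homo sapiens) for inhibition, read by MTT assay, with a stated time of 48 h, tested at 10 uM (on this read-out higher numbers stand for more inhibition of growth at the one concentration tested and lower numbers for less inhibition of growth), with compound 1 its nearest neighbour; the step of a number 2 percentage points lower from compound 1 to compound 2 (within the scatter) is within the scatter, so the two values are not distinguished. The compound to be measured next is compound 3 `COc1ccc(C(=O)/C=C/c2ccc(OCc3cn(Cc4ccc(F)cc4)nn3)cc2)cc1`. It differs from compound 2 by fluoro in place of bromo on an aromatic carbon. Among the compounds with values here, no measured step bears directly on this change: the only step on record, from compound 1 to compound 2, moves the bromo group around the ring and leaves it in place, and that move produced no change beyond the scatter. The halogen on the benzyl ring therefore appears, on the evidence here, not to drive the read-out. The step of a number 2 percentage points lower from compound 2 to compound 3 (within the scatter) is expected to stay within the scatter. For compound 3 in this assay the estimate is 48%, with a range from 35% to 60%.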

Compound 3, percent growth inhibition at one concentration: 33%
Compound 3: middle estimate off by 15 percentage points, on the high side, and the stated range ends above it.
By their numbers in this assay, from the lowest: compound 3; then compounds 2 and 1 (each within the scatter of the next).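

In this assay the identity of the halogen on this aromatic carbon now matters: the exchange of bromo for fluoro gives a number 17 percentage points lower from compound 2 to compound 3 (beyond the scatter) and thus shows a sensitivity that moving the bromo group around the ring had not revealed. The change to 4-fluorophenyl from 2-bromophenyl gives a number 19 percentage points lower from compound 1 to compound 3 (beyond the scatter) and points the same way, so the fluoro compound stands apart from both bromo compounds, which remain within the scatter of each other. Nothing measured here accounts for this difference.

Open, going by these compounds, is how chloro, methyl or methoxy on this aromatic carbon would read, and so whether the series follows any order across such groups. Also open, on these data alone, is whether fluoro elsewhere on the ring would read like compound 3 or differently.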